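This account rests on a few compounds, and the source may have more. Where it says the series, first, only, none or still open, it means among the compounds named here.

Compound 1 `COc1cccc(C(=O)c2ccc3c(ccn3S(=O)(=O)c3cccc(/C=C/C(=O)NO)c3)c2)c1` gives 1810 nM in an assay on isolated protein for inhibition of protein deacetylase HDAC6 (Homo sapiens) (a higher number here means a weaker inhibitor, a lower number a stronger inhibitor), the higher of the two values recorded, while compound 2 `COc1ccc(C(=O)c2ccc3c(ccn3Cc3ccc(C(=O)NO)cc3)c2)cc1` gives 3.92 nM in this assay; these two compounds differ in more than one place, so their gap is noted without being traced to a single change. Compound 3 `COc1ccc(C(=O)c2ccc3c(ccn3S(=O)(=O)c3cccc(/C=C/C(=O)NO)c3)c2)cc1OC` differs from compound 1 by methoxy in place of hydrogen on an aromatic carbon. Within the data shown here, no measured pair shows what such a change does on this core, so the step of a 1.2-fold lower number from compound 1 to compound 3 (0.08 log units; within the scatter) is expected to be small, in no firm direction, and within the usual scatter. Compound 3 is accordingly estimated at 1500 nM, with a range from 500 nM to 4500 nM.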

Compound 3, half-maximal inhibitory concentration: 1180 nM
The estimate for compound 3 lay 1.3-fold (0.10 log units) above the measured number; the measured number falls inside the stated range.
By their numbers in this assay, from the lowest: compound 2; then compounds 3 and 1 (each within the scatter of the next).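

Among these compounds, with a 1.5-fold lower number from compound 1 to compound 3 (0.19 log units; within the scatter) in this assay, the first measured pair on this core shows that methoxy in place of hydrogen on this aromatic carbon, ortho to a methoxy group and para to a large group, leaves compound 1 and compound 3 indistinguishable. Going from 3-methoxyphenyl to 3,4-dimethoxyphenyl thus gives no measurable gain or loss on the shared core. Nothing available bears on the reason for this result. As far as these compounds go, whether an amine, a carboxylic acid or a longer chain on this carbon would read the same remains open. So does which of the several differences between compound 1 and compound 2 carries their gap.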